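Weakly Active Analogues and One Untested Acetamide

A few compounds are considered here, and "the series" means these few. Any claim that something is new, unique, unknown or untested is made for them only; others in the source may bear on it.

In a functional assay on SMMC-7721 cells (Homo sapiens) for inhibition, read by MTT assay, with a stated time of 48 h (on this read-out lower numbers stand for stronger inhibition and higher numbers for weaker inhibition), compound 1 `Cc1cc2c(NCc3cccnc3N(C)S(C)(=O)=O)nc(Nc3ccc4c(c3)CC(=O)N4)nc2[nH]1` reaches only the limit > 100000 nM. Compound 2 `CN(c1ncccc1CNc1nc(Nc2ccc3c(c2)CC(=O)N3)nc2[nH]cc(F)c12)S(C)(=O)=O` gives 73200 nM. Compound 3 `CN(c1ncccc1CNc1nc(Nc2cccc(C#N)c2)nc2[nH]cc(F)c12)S(C)(=O)=O` likewise reaches only the limit > 100000 nM. Within the data shown here, the one measured step bearing on compound 3 is an at least 1.3-fold higher number from compound 2 to compound 3 (0.13 log units; that floor lies within the scatter). Compound 3 thus stands among the limit values rather than the measured numbers, as the limit of > 100000 nM in this assay, at which 2 of the 3 values shown sit, records. Compound 4 `CC(=O)NCc1cccc(Nc2nc(NCc3cccnc3N(C)S(C)(=O)=O)c3c(F)c[nH]c3n2)c1` differs from compound 3 in one place: acetamidomethyl in place of cyano on an aromatic carbon. Among the measured compounds shown here, no measured step varies this position, so the step of a number no higher from compound 3 to compound 4 (the limit leaves the size open) is expected to stay within the scatter. Compound 4 is estimated at 100000 nM, with a range from 30000 nM to 300000 nM, and a limit rather than a number remains likely in this assay.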

Compound 4, half-maximal inhibitory concentration: 21700 nM
The estimate for compound 4 lay 4.6-fold (0.66 log units) above the measured number, and the stated range ends above it.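

Acetamidomethyl in place of cyano on this aromatic carbon gives a change that clears the scatter in this assay, which the earlier step at this place could not show: an at least 4.6-fold lower number from compound 3 to compound 4 (0.66 log units; beyond the scatter). The open 3-(acetamidomethyl)phenyl group also compares favourably with the group carried by compound 2, with a 3.4-fold lower number from compound 2 to compound 4 (0.53 log units; beyond the scatter). The first step has only a floor because compound 3 stands at a limit: the limit of > 100000 nM in this assay, at which 2 of the 4 values shown sit.

The compounds shown leave open whether an aminomethyl group, a carboxylic acid or a longer chain on this carbon would lower the number further.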